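The compounds below may be only part of what the source reports. "The series", "measured", "known", "first", "only" and "open" are said of these compounds alone.

Of the compounds shown here, two have so far been tested in a functional assay on MDA-MB-231 cells (Homo sapiens) for cytotoxicity, read by MTT assay, with a stated time of 48 h; on this read-out lower numbers stand for stronger inhibition and higher numbers for weaker inhibition. Compound 1, `O=C1C[C@H](OCc2cn(C3CCCCC3)nn2)[C@H]2CO[C@@H]1O2`, gives 24300 nM in this assay. Compound 2, `COC(=O)Cn1cc(CN(C(C)=O)[C@H]2CC(=O)[C@@H]3OC[C@H]2O3)nn1`, reaches only the ceiling of this assay and gives > 50000 nM; that figure is a limit of the measurement rather than a number, and it marks (the limit of > 50000 nM in this assay, at which 1 of the 2 values shown sits). Of the two values shown, compound 2 thus sits at the weak end, with no measured number of its own, while compound 1 has a measured value.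

Compound 3, `CCCCCCCCn1cc(CN(C(C)=O)[C@H]2CC(=O)[C@@H]3OC[C@H]2O3)nn1`, is the next compound to be measured in this assay. It differs from compound 2 in a single place: heptyl in place of methoxycarbonyl on a saturated chain carbon bound to an aromatic nitrogen. Read one bond further out, the short ester-bearing chain on the aromatic nitrogen is exchanged for a plain octyl chain.

No measured step of this kind exists among the compounds shown, so the size of the change is open. Compound 3 is nevertheless expected to come back to a measurable value, which would mean a step of an at least 2.0-fold lower number from compound 2 to compound 3 (0.30 log units; that floor lies within the scatter) from the limit. Compound 3 is estimated at 25000 nM, somewhere between 8000 nM and 80000 nM, with a real chance that it too only reaches the limit.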

Compound 3, half-maximal inhibitory concentration: > 50000 nM
Compound 3: no number, only a limit; the forecaster's own chance of this, stated with the estimate: 40%; at least 2.0-fold (0.30 log units) between middle value and limit.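

In this assay compound 3 gives > 50000 nM, which is a limit of the assay and not a number. Compound 2 sits at the same limit, so no step can be read between compound 2 and compound 3. The compounds shown leave open how weak either one really is, and whether exchanging (methoxycarbonyl)methyl for octyl changes the read-out at all.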